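The source may report more compounds than this note shows. Statements on the series, on what has been measured and on what is new or still open speak of the compounds shown alone.

Measured so far:
compound 1, `c1cn2cc(-c3ccsc3)nc(-c3ccc4ncn(C5CCCCC5)c4c3)c2n1`, with 13.4% in a functional assay on HCT-116 cells (Homo sapiens) for inhibition, read by sulforhodamine B assay, with a stated time of 48 h, tested at 10 uM; a lower number here means less inhibition, a higher number more inhibition at the concentration tested (going by the name of the read-out)
compound 2, `c1cn2cc(-c3ccc4c(c3)ncn4C3CCCCC3)nc(-c3ccc4ncn(C5CCCCC5)c4c3)c2n1`, with 29.1% in this assay

Of the two numbers, compound 2 stands highest, and its nearest neighbour, compound 1, lies below it by a gap that is beyond the usual scatter. The pair differ in more than one place, so the gap between them cannot be assigned to any single change; the two values merely show that compound 2 gave more inhibition in this assay than compound 1.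

The account now follows compound 2 to compound 3, `c1ccc(Cn2cnc3ccc(-c4nc(-c5ccc6c(c5)ncn6C5CCCCC5)cn5ccnc45)cc32)cc1`, which has not yet been measured. The change from compound 2 to compound 3 is this: benzyl in place of cyclohexyl on an aromatic nitrogen. Among the compounds with values here, it is a benzyl in place of cyclohexyl on an aromatic nitrogen, and nothing among the measured pairs shows how such a swap moves the read-out.

Within the data shown here, with no measured step to lean on, compound 3 is expected to stay close to compound 2, and the step of a number 2.1 percentage points lower from compound 2 to compound 3 (within the scatter) is estimated to be none beyond the scatter, in either direction. For compound 3 the estimated value in this assay is 27%, within a range from 10% to 45%.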

Compound 3, a percentage reported as inhibition, at one concentration (the size of the read-out at that concentration, not a potency): -75.8%
Compound 3: the middle estimate sits 102.8 percentage points above what was measured; measured number outside the range, below it.
By their numbers in this assay, from the lowest: compound 3; then compound 1; then compound 2.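

Benzyl in place of cyclohexyl on this aromatic nitrogen gives a number 104.9 percentage points lower from compound 2 to compound 3 (beyond the scatter) in this assay, so this position is sensitive to the choice between these two groups, even though each brings one six-membered ring of carbon only and neither brings a hydrogen-bond donor or acceptor. Compound 3 gives -75.8%, a negative number, so the read-out does not merely shrink towards no inhibition but passes beyond it. Nothing available here accounts for this shift.

This single swap leaves open whether the drop goes with the aromatic ring of the benzyl group or with the extra carbon that joins that ring to the nitrogen, a question that a phenyl group placed directly on the nitrogen or a longer phenethyl chain could help to separate. It also leaves open how a simple methyl group or a piperidine amine on this nitrogen would read in this assay, and whether the same swap on the other cyclohexyl-bearing nitrogen of compound 2 would move the number in the same way.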